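From (piperidin-1-yl)methyl to (morpholin-4-yl)carbonyl

The source may report more compounds than this note shows. Statements on the series, on what has been measured and on what is new or still open speak of the compounds shown alone.

Of the compounds shown here, two sharing one core have been measured in a functional assay on A549 cells (Homo sapiens) for cytotoxicity, read by MTT assay, with a stated time of 72 h; on this read-out lower numbers stand for stronger inhibition and higher numbers for weaker inhibition. Compound 1 (`COc1ncc(-c2ccc3nc(NC(=O)NCC(=O)N4CCCCC4)nn3c2)cc1NS(=O)(=O)c1ccc(F)cc1`) gives 2060 nM, and compound 2 (`COc1ncc(-c2ccc3nc(NC(=O)NCCN4CCCCC4)nn3c2)cc1NS(=O)(=O)c1ccc(F)cc1`) gives 610 nM, the lower of the two numbers. Going by the values given here, they are linked by the only measured step, a 3.4-fold lower number from compound 1 to compound 2 (0.53 log units; beyond the scatter), which puts (piperidin-1-yl)methyl in place of (piperidin-1-yl)carbonyl on a saturated chain carbon bound to an amide-type nitrogen.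

Compound 3 (`COc1ncc(-c2ccc3nc(NC(=O)NCC(=O)N4CCOCC4)nn3c2)cc1NS(=O)(=O)c1ccc(F)cc1`) carries (morpholin-4-yl)carbonyl in place of the (piperidin-1-yl)methyl of compound 2 at that same place: (morpholin-4-yl)carbonyl in place of (piperidin-1-yl)methyl on a saturated chain carbon bound to an amide-type nitrogen. Two things change at once. The carbonyl returns, so the measured step for compound 2, a 3.4-fold lower number from compound 1 to compound 2 (0.53 log units; beyond the scatter), bears on this change when read backwards. Among the compounds with values here, the ring also changes, and no measured pair shows that change alone. A step of similar size towards a higher number is therefore expected in this assay, with added uncertainty from the ring. The estimated change is a 3.6-fold higher number from compound 2 to compound 3 (0.56 log units; beyond the scatter). Compound 3 is expected at 2200 nM, with an estimated range from 900 nM to 5500 nM.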

Compound 3, half-maximal inhibitory concentration: 2570 nM
Compound 3: middle estimate off by 1.2-fold (0.07 log units), on the low side; the measured number falls inside the stated range.
By their numbers in this assay, from the lowest: compound 2; then compounds 1 and 3 (each within the scatter of the next).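

The new pair isolates the ring at this place: with the carbonyl kept, morpholin-4-yl in place of piperidin-1-yl on a carbonyl carbon gives a 1.2-fold higher number from compound 1 to compound 3 (0.10 log units; within the scatter) in this assay, so compound 1 and compound 3 cannot be told apart here. The larger change, (morpholin-4-yl)carbonyl in place of (piperidin-1-yl)methyl, gives a 4.2-fold higher number from compound 2 to compound 3 (0.62 log units; beyond the scatter), which runs opposite to a 3.4-fold lower number from compound 1 to compound 2 (0.53 log units; beyond the scatter); among these three compounds, therefore, the two carrying the carbonyl both give higher numbers than compound 2, whichever ring they carry. No measurement shown here explains why the numbers fall this way.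

As far as these compounds go, what remains open is whether the ring is equally silent without the carbonyl, which a (morpholin-4-yl)methyl group at this same place on a saturated chain carbon bound to an amide-type nitrogen would test. From the compounds shown here alone, it is also open how far the lower number of compound 2 extends to other groups here, such as an open-chain dimethylamine, a piperazine ring or a longer chain ahead of the piperidine ring.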